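This account rests on a few compounds, and the source may have more. Where it says the series, first, only, none or still open, it means among the compounds named here.

Compound 1 `FC(F)(F)c1cccc(/N=N/N2CCCC2)c1` gives in an ADME assay on BHK-21 cells (Mesocricetus auratus) for cytotoxicity, read by MTT assay, with a stated time of 96 h (on this read-out lower numbers stand for higher toxicity in this test and higher numbers for lower toxicity in this test), a value that is a limit of the assay, > 100000 nM.
Compound 2 `CN(C)CCCN(/N=N/c1ccccc1)c1cccc(C(F)(F)F)c1` gives in this assay the value 49000 nM.
Compound 3 `c1ccc(/N=N/N2CCCC2)cc1` gives in this assay a value that is again a limit of the assay, >= 100000 nM.

From compound 1 to compound 3 the change is hydrogen in place of trifluoromethyl on an aromatic carbon. The step it made, a step that the two limits leave unreadable from compound 1 to compound 3, cannot be read because the limit of > 100000 nM in this assay, at which 1 of the 3 values shown sits, and the limit of >= 100000 nM in this assay, at which 1 of the 3 values shown sits, sit on either side of it. Compound 2 is the only one of the three with a number rather than a limit. How the core of compound 2 differs from the core of compound 1 is not broken down here.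

Compound 4 `CN(C)CCCN(/N=N/c1ccccc1)c1ccccc1` has not yet been measured. It comes from compound 2 by hydrogen in place of trifluoromethyl on an aromatic carbon, the same kind of change as before, though here the place is meta to a large group rather than meta to a group of 7 heavy atoms. Among the compounds with values here, the only measured instance of this change, a step that the two limits leave unreadable from compound 1 to compound 3, offers no size to lean on, so the step expected from compound 2 to compound 4 is a modest one, a 1.4-fold higher number from compound 2 to compound 4 (0.15 log units; within the scatter). Compound 4 is therefore estimated at 70000 nM, between 30000 nM and 150000 nM.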

Compound 4, half-maximal cytotoxic concentration: 50000 nM
Compound 4: the middle estimate sits 1.4-fold (0.15 log units) above what was measured, and the stated range covers the measured number.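

In this assay, putting hydrogen in place of trifluoromethyl on the core of compound 2 gives a 1.0-fold higher number from compound 2 to compound 4 (0.01 log units; within the scatter), so on this core the swap makes no difference that can be told apart from repeat measurements. Within the data shown here, the same swap on the core of compound 1 cannot be read: both ends of that step are limits of the assay, so the two cores offer no pair of sizes to compare. This means the flat result is one readable case on one core, and it does not show that the swap would stay flat when carried to another core.

The compounds shown leave open how a nitrile or a carboxylic acid would read at the same place on the aromatic ring, where only trifluoromethyl and hydrogen appear. They also leave open whether a longer chain carrying the dimethylamino group would shift the number for compound 2 or compound 4.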